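Solubility notes: aryl amine swap on the shared core

The compounds below may be only part of what the source reports. "The series", "measured", "known", "first", "only" and "open" are said of these compounds alone.

Among the compounds with values here, compound 2 `CCOc1cc2nnc(C(N)=O)c(Nc3cc(C)ccc3F)c2cc1N1CCN(C)CC1` gives 120000 nM in a physicochemical assay for solubility (a lower number here means a less soluble compound, a higher number a more soluble compound), the highest of the two numbers measured so far; compound 1 `CCOc1cc2nnc(C(N)=O)c(Nc3ccc(C)cc3F)c2cc1N1CCN(C)CC1` gives 27000 nM. Within the data shown here, the one measured step, a 4.4-fold higher number from compound 1 to compound 2 (0.65 log units; beyond the scatter), concerns only where the methyl sits on the same aryl ring and bears little on the present change. Compound 3 `CCOc1cc2nnc(C(N)=O)c(Nc3cccc(Cl)c3Cl)c2cc1N1CCN(C)CC1` carries 2,3-dichlorophenyl in place of 2-fluoro-5-methylphenyl on a nitrogen on an aromatic ring. Among the measured compounds shown here, with no step addressing this exchange, the estimate for compound 3 in this assay is 40000 nM, with a range from 10000 nM to 150000 nM. The expected step of a 3.0-fold lower number from compound 2 to compound 3 (0.48 log units; beyond the scatter) is a modest decrease, though the range admits none beyond the scatter.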

Compound 3, solubility: 10000 nM
Estimate against measurement, compound 3: 4.0-fold (0.60 log units) above, and the stated range covers the measured number.
By their numbers in this assay, from the lowest: compound 3; then compound 1; then compound 2.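

In this assay, 2,3-dichlorophenyl on a nitrogen on an aromatic ring gives a 12-fold lower number from compound 2 to compound 3 (1.08 log units; beyond the scatter), and a 2.7-fold lower number from compound 1 to compound 3 (0.43 log units; beyond the scatter). This position therefore tolerates more than a methyl shift: exchanging both substituents on the aryl ring takes compound 3 beneath both fluoro-methyl compounds, with a large step from compound 2 and a modest one from compound 1. Nothing available accounts for this difference.

Fluorine and methyl leave together here, so the share of each chlorine stays unresolved. Going by these compounds, how an aryl ring carrying an amine or a carboxylic acid would compare also remains open.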